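A Chloro Substituent on the Sulfo Analogue

The source may report more compounds than this note shows. Statements on the series, on what has been measured and on what is new or still open speak of the compounds shown alone.

Of the compounds shown here, three built on one shared core have been tested in a functional assay on thoracic aorta for antagonist activity at thromboxane A2 receptor (Rattus norvegicus); a lower number here means a stronger inhibitor, a higher number a weaker inhibitor. Compound 1, `CC(C)c1ccc2c(CCCC(=O)NS(=O)(=O)c3ccccc3)cc(C(=O)O)c-2cc1`, gives only a limit of the assay, > 100000 nM (the limit of > 100000 nM in this assay, at which 1 of the 3 values shown sits). Compound 2, `CC(C)c1ccc2c(CCCC(=O)NS(=O)(=O)c3ccc(Cl)cc3)cc(C(=O)O)c-2cc1`, carries chloro in place of hydrogen on an aromatic carbon and gives 19000 nM; the step of an at least 5.2-fold lower number from compound 1 to compound 2 (0.72 log units; beyond the scatter) is the clearest change seen so far. Compound 3, `CC(C)c1ccc2c(CCCC(=O)NS(=O)(=O)c3ccccc3)cc(S(=O)(=O)O)c-2cc1`, carries sulfo in place of carboxy on an aromatic carbon and gives 65000 nM; the step of an at least 1.5-fold lower number from compound 1 to compound 3 (0.18 log units; that floor lies within the scatter) cannot be sized beyond its floor. Of the two real numbers, compound 3 stands highest, with compound 2 nearest, a gap beyond the scatter.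

Compound 4, `CC(C)c1ccc2c(CCCC(=O)NS(=O)(=O)c3ccc(Cl)cc3)cc(S(=O)(=O)O)c-2cc1`, is not yet measured. It differs from compound 3 by chloro in place of hydrogen on an aromatic carbon. Among the measured compounds shown here, the only measured step of this kind is an at least 5.2-fold lower number from compound 1 to compound 2 (0.72 log units; beyond the scatter), which lowered the number beyond the scatter, so a modest downward step is expected in this assay here as well. The estimate for compound 4 is therefore 12000 nM, between 4000 nM and 40000 nM. This means that a 5.4-fold lower number from compound 3 to compound 4 (0.73 log units; beyond the scatter) is expected.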

Compound 4, half-maximal inhibitory concentration: 54000 nM
For compound 4 the middle estimate is 4.5-fold (0.65 log units) below the measured one; measured number above the stated range.
By their numbers in this assay, from the lowest: compound 2; then compounds 4 and 3 (each within the scatter of the next). At a limit, above all of these: compound 1.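

This result shows that chloro in place of hydrogen on this aromatic carbon does not have one fixed effect in this assay: with sulfo on the core instead of carboxy, the step shrinks to a 1.2-fold lower number from compound 3 to compound 4 (0.08 log units; within the scatter), so its size depends on the group elsewhere on the core: the same change on two cores in this assay, an at least 5.2-fold lower number (0.72 log units; beyond the scatter) from compound 1 to compound 2 and a 1.2-fold lower number (0.08 log units; within the scatter) from compound 3 to compound 4, at least 4.3-fold (0.64 log units) apart, beyond the scatter of two such steps. It also gives the first fully measured size for sulfo in place of carboxy, and with the chloro present that swap weakens the compound, a 2.8-fold higher number from compound 2 to compound 4 (0.45 log units; beyond the scatter). Without the chloro, the same swap can be read only as a floor, since compound 1 stands at a limit, yet the two swaps still differ: the same change on two cores in this assay, an at least 1.5-fold lower number (0.18 log units; that floor lies within the scatter) from compound 1 to compound 3 and a 2.8-fold higher number (0.45 log units; beyond the scatter) from compound 2 to compound 4, at least 4.3-fold (0.64 log units) apart, beyond the scatter of two such steps.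

Why these two changes depend on each other stays open. The compounds shown also leave open whether bromo or methyl in place of chloro, or a phosphonic acid in place of sulfo, would behave the same way.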